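Hexyl in place of phenyl on an aromatic nitrogen

The source may report more compounds than this note shows. Statements on the series, on what has been measured and on what is new or still open speak of the compounds shown alone.

Compound 1 `OC[C@H]1OC(n2cnc3c(Nc4ccccc4)nccc32)[C@H](O)[C@@H]1O` gives 10% in a functional assay on EL4 cells (Mus musculus) for inhibition, tested at 100 uM; on this read-out lower numbers stand for less inhibition and higher numbers for more inhibition at the one concentration tested (going by the name of the read-out).
Compound 2 `OC[C@H]1O[C@@H](n2cnc3cnccc32)[C@H](O)[C@@H]1O` reaches only the limit of this assay, reported as < 5%; < 5% (2 entries), twice.

For the measured compounds named here, compound 1 is the only compound here with an actual number in this assay; compound 2 returned a limit rather than a number, and its pair has no counted difference to compound 1, so the two values say only that both sit low. Compound 3 `CCCCCCNc1nccc2c1ncn2C1O[C@H](CO)[C@@H](O)[C@H]1O` has not been measured. It differs from compound 1 as follows: hexyl in place of phenyl on a nitrogen on an aromatic ring. Going by the values given here, no step between two measured compounds is available to say how such a swap plays out in this assay. With compound 1 already low, the step from compound 1 to compound 3 is expected to stay within the usual scatter, in no clear direction, no change at the digits printed from compound 1 to compound 3 (within the scatter). Compound 3 is therefore estimated at 10%, within 0% to 25%.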

Compound 3, a percentage reported as inhibition, at one concentration (the size of the read-out at that concentration, not a potency): 14%
Estimate against measurement, compound 3: 4 percentage points below; the range from low to high includes it.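

On the nitrogen on the aromatic ring, exchanging phenyl for hexyl in this assay gives a number 4 percentage points higher from compound 1 to compound 3 (within the scatter), so this one comparison shows no measurable effect of the change. The two groups have the same count of carbon atoms, and replacing the aromatic ring with an open chain of that size leaves the read-out at this single concentration indistinguishable, so at this position the ring is not needed to keep this low level of inhibition, and hexyl does not raise it beyond the scatter. Nothing measured here offers an explanation for this outcome.

From the compounds shown here alone, whether a different kind of group on this nitrogen, such as a chain ending in an amine or a carboxylic acid, or a longer chain, would move the read-out remains open. So does how these compounds would behave at any other concentration, since a single tested concentration gives no potency.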